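Swapping Chloro for Methoxy Beside the Amine Side Chain

The compounds below may be only part of what the source reports. "The series", "measured", "known", "first", "only" and "open" are said of these compounds alone.

Of the compounds shown here, three that share one core have been tested in an assay on isolated protein for inhibition of AP2-associated protein kinase 1 (Homo sapiens), with a stated time of 3 h, in the presence of a further agent that is not named here; on this read-out lower numbers stand for stronger inhibition and higher numbers for weaker inhibition. Compound 1 `COC(=O)Nc1cc(-c2cnc(OC[C@@](C)(N)CC(C)C)c(Cl)c2)ccn1` gives 0.4 nM, the lowest number among the three. Compound 2 `CC(=O)Nc1cc(-c2ccc(OC[C@@H](N)CC(C)C)c(Cl)c2)ccn1` gives 0.5 nM, which sits within the usual scatter of that result, so the two cannot be told apart. Compound 3 `COC(=O)Nc1cc(-c2ccc(OC[C@@](C)(N)CC(C)C)c(C)c2C)ccn1` gives 4.5 nM, a number that lies beyond the scatter above compound 1.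

Compound 4 `COC(=O)Nc1cc(-c2cnc(OC[C@@](C)(N)CC(C)C)c(OC)c2)ccn1` has not yet been tested. It differs from compound 1 in a single spot: methoxy in place of chloro on an aromatic carbon, on an aromatic carbon of a six-membered aromatic ring with one nitrogen, ortho to the (2-amino-2,4-dimethylpentyl)oxy group and two atoms from the ring nitrogen. Among the measured compounds shown here, no measured pair among the three compounds shows this particular exchange, so the size of the change is open. A modest step in this assay is expected, with weaker inhibition somewhat more likely than stronger, but a result within the scatter would not surprise. The expected step from compound 1 to compound 4 is a 2.5-fold higher number from compound 1 to compound 4 (0.40 log units; beyond the scatter). Compound 4 is therefore estimated at 1 nM, with a likely range from 0.3 nM to 4 nM.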

Compound 4, half-maximal inhibitory concentration: 3.8 nM
Beside the measured number, compound 4's estimate is 3.8-fold (0.58 log units) below it; the measured number falls inside the stated range.
By their numbers in this assay, from the lowest: compounds 1 and 2 (each within the scatter of the next); then compounds 4 and 3 (each within the scatter of the next).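

In this assay, methoxy in place of chloro on this aromatic carbon, ortho to the (2-amino-2,4-dimethylpentyl)oxy group, gives a 9.5-fold higher number from compound 1 to compound 4 (0.98 log units; beyond the scatter) and so shows that the number responds to what sits at this position. The earlier compounds shown here could not show this, as no two of them differ in one place only. The exchange replaces a group with no hydrogen-bond acceptor by one with a hydrogen-bond acceptor and one more heavy atom, but nothing available here links either feature to the step.

On these data alone, whether a fluoro group, a methyl group or a plain hydrogen on this carbon would stay close to compound 1 or move toward compound 4 remains open. So does whether the same exchange would give a step of similar size on the core of compound 2.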